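Methyl for hydrogen on the core of compound 1

This account rests on a few compounds, and the source may have more. Where it says the series, first, only, none or still open, it means among the compounds named here.

Measured compounds in an in vitro ADME assay on microsomes (Homo sapiens) for metabolic stability; on this read-out higher numbers stand for a longer-lived compound and lower numbers for a shorter-lived compound:
compound 1 `CCC(CC)Nc1nc(OC)c(-c2ccc(Cl)cc2Cl)nc1C`: 0.933 h
compound 2 `CCc1nc(NC(CC)CC)c(F)nc1-c1ccc(Cl)cc1Cl`: 1.22 h
compound 3 `CCOc1nc(-c2ccc(Cl)cc2Cl)c(CC)nc1NC(CC)CC`: 2 h

Compound 1 gives the lowest of the three numbers in this assay. Compound 2 lies within the scatter of it, and only compound 3 stands beyond the scatter from compound 1. Within the data shown here, the one step measured between a pair that differs in a single place, a 1.6-fold higher number from compound 2 to compound 3 (0.21 log units; within the scatter), concerns a change on an aromatic carbon and does not touch the part of the core altered here.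

Compound 4 `CCc1nc(-c2ccc(Cl)cc2Cl)c(OC)nc1NC(CC)CC` differs from compound 1 as follows: methyl in place of hydrogen on a saturated chain carbon bound to an aromatic carbon. Among the measured compounds shown here, no measured pair isolates this change; compounds 2 and 3 carry the larger group but also differ from compound 1 elsewhere, so their values show only that the shared core tolerates it without a marked loss in this assay. In the absence of a direct precedent, the change from compound 1 to compound 4 is expected to stay within the scatter, with a slight lean upward given that compound 3, which carries the same group, gives 2 h.

Compound 4 is therefore estimated at 1.2 h in this assay, between 0.6 h and 2.4 h, an expected step of a 1.3-fold higher number from compound 1 to compound 4 (0.11 log units; within the scatter).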

Compound 4, half-life: 0.7 h
For compound 4 the middle estimate is 1.7-fold (0.23 log units) above the measured one, within the range that was stated.
By their numbers in this assay, from the lowest: compounds 4, 1, 2 and 3 (each within the scatter of the next, the first and the last beyond it).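

In this assay the change can now be read on its own, with a 1.3-fold lower number from compound 1 to compound 4 (0.12 log units; within the scatter) placing methyl in place of hydrogen on a saturated chain carbon bound to an aromatic carbon, which cut one bond further out reads methyl to ethyl. Among these compounds, compounds 2 and 3 carry the ethyl group but also differ from compound 1 elsewhere, so this pair is the first to separate the change from the rest of the structure, and the step stays within the scatter. No measured evidence bears on why this position responds as it does.

Open, on these data alone, is whether a longer chain such as propyl, or a small ring such as cyclopropyl, in this place would carry the number beyond the scatter. Also open, as far as these compounds go, is whether methyl to ethyl reads the same way when fluoro, as in compound 2, or ethoxy, as in compound 3, stands on the aromatic carbon that bears the methoxy group in compound 1 and compound 4.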